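A ring substituent swap from compound 2 to compound 4

This account rests on a few compounds, and the source may have more. Where it says the series, first, only, none or still open, it means among the compounds named here.

Values in a physicochemical assay for solubility, read by turbidimetry, measured as kinetic solubility, at pH 7.4 (on this read-out higher numbers stand for higher solubility and lower numbers for lower solubility), for three compounds
compound 1 `CC1SC(c2cccc(C(=O)NCCCCc3ccccc3)c2)N(c2ccc(C3CC3)cc2)C1=O` gives 2000 nM here
compound 2 `COc1ccc(F)cc1N1C(=O)CSC1c1cccc(C(=O)NCCCCc2ccccc2)c1` gives 10000 nM here
compound 3 `Cc1cccc(N2C(=O)CSC2c2cccc(C(=O)NCCCCc3ccccc3)c2)c1` gives 10000 nM here

Compound 2 stands level with compound 3 at the top of these three numbers, while compound 1 sits lower, beyond the scatter. The change to compound 4 `CC(F)(F)c1cccc(N2C(=O)CSC2c2cccc(C(=O)NCCCCc3ccccc3)c2)c1` falls on an amide-type nitrogen in a ring (a group of 10 heavy atoms (8 carbon, 2 fluorine; one six-membered aromatic ring of carbon only) in place of a group of 9 heavy atoms (7 carbon, 1 oxygen, 1 fluorine; one six-membered aromatic ring of carbon only), on an amide-type nitrogen in a ring) and leaves the rest of the molecule as it is. Within the data shown here, one measured step bears directly on this place: no change at the digits printed from compound 2 to compound 3 (within the scatter) is a move within the scatter. Among the measured compounds shown here, compound 1 also carries another group there, but it differs elsewhere too, so its value (2000 nM) offers no clean step, only a sign that lower numbers occur in this small set. No step beyond the scatter is therefore expected in this assay and any move is expected to lean downward. The estimated change (a 1.7-fold lower number from compound 2 to compound 4 (0.22 log units; within the scatter)) is thus a modest one. In this assay compound 4 is expected at 6000 nM with an estimated range of 2000 nM to 12000 nM around it.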

Compound 4, solubility: 2000 nM
The estimate for compound 4 lay 3.0-fold (0.48 log units) above the measured number, within the range that was stated.
By their numbers in this assay, from the lowest: compounds 1 and 4 (each within the scatter of the next); then compounds 2 and 3 (each within the scatter of the next).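

Among these compounds, the ring-nitrogen substituent had so far moved the number only within the scatter, but this position can clearly shift this assay beyond it: the change gave a 5.0-fold lower number from compound 2 to compound 4 (0.70 log units; beyond the scatter) in this set. The cleaner comparison is a single swap on the aromatic carbon, 1,1-difluoroethyl in place of methyl, which gave a 5.0-fold lower number from compound 3 to compound 4 (0.70 log units; beyond the scatter) and so locates the shift in that one group, not in the loss of the 5-fluoro-2-methoxyphenyl pattern. Nothing measured here accounts for the shift.

The compounds shown leave open whether the shift follows the two fluorine atoms or the larger carbon group, which an ethyl group on the same aromatic carbon would help to separate. They also leave open whether an amine on that aromatic ring would hold the number at the level of compound 3.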